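A few compounds are considered here, and "the series" means these few. Any claim that something is new, unique, unknown or untested is made for them only; others in the source may bear on it.

Compound 1, `Cn1cnc2c(-c3ccccc3)ncnc21`: 8%
Compound 2, `Cn1cnc2c(-c3ccc(F)cc3)ncnc21`: 12%
Compound 3, `Cn1c(-c2ccccc2)nc2c(Sc3ccccc3)ncnc21`: 1%

All three were tested in an assay on isolated protein for inhibition of Ca2+/calmodulin-dependent protein kinase II (CaM kinase II) (Rattus norvegicus), tested at 30 uM; on this read-out higher numbers stand for more inhibition at the one concentration tested (going by the name of the read-out) and lower numbers for less inhibition. Compound 1 gives 8% there, and compound 2, which carries fluoro in place of hydrogen on an aromatic carbon, gives 12%; this is a number 4 percentage points higher from compound 1 to compound 2 (within the scatter). Compound 3 shows 1%; how its core differs from the core of compound 1 is not broken down here. Compound 4, `Cn1c(-c2ccccc2)nc2c(Sc3ccc(F)cc3)ncnc21`, has not been measured. It differs from compound 3 by fluoro in place of hydrogen on an aromatic carbon, the same change as between compound 1 and compound 2. For compound 4 the expected step is a number 3 percentage points higher from compound 3 to compound 4 (within the scatter), because the earlier step was a number 4 percentage points higher from compound 1 to compound 2 (within the scatter) and the surroundings of the change are described in the same words. Compound 4 is therefore estimated at 4%, with a range from -5% to 13%.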

Compound 4, a percentage reported as inhibition, at one concentration (the size of the read-out at that concentration, not a potency): 8%
Estimate against measurement, compound 4: 4 percentage points below, and the stated range covers the measured number.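

On this assay, fluoro in place of hydrogen on an aromatic carbon, here phenylsulfanyl to (4-fluorophenyl)sulfanyl, gives a number 7 percentage points higher from compound 3 to compound 4 (within the scatter). Set beside the step on the other core, the two do not differ: the same change on two cores in this assay, a number 4 percentage points higher (within the scatter) from compound 1 to compound 2 and a number 7 percentage points higher (within the scatter) from compound 3 to compound 4, 3 percentage points apart, within the scatter of two such steps. This shows that the change reads alike on both cores, but with each step inside the scatter it does not show that fluoro raises inhibition on either core, and two cores say nothing about any others.

The compounds shown carry only hydrogen or fluoro at this place on the ring. As far as these compounds go, it remains open whether a chloro group, an amine or a carboxylic acid there would move the number beyond the scatter.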